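The source may hold more compounds than are shown below. What is called first, only, known or untested is meant among the compounds shown, and "the series" means these compounds.

Measured in an ADME assay on microsomes from liver (Homo sapiens) for metabolic stability, with a stated time of 60 min, tested at 1 uM; on this read-out lower numbers stand for a less stable compound and higher numbers for a more stable compound:
Compound 1 `COc1cc(-c2cnn3cc(OC)c(C4CCOC4)nc23)ccn1`: 29%
Compound 2 `COc1cn2ncc(-c3ccnc(OC(C)(C)C)c3)c2nc1-c1cnn(C)c1`: 35%

In this assay, compound 1 stands at 29%, within the scatter of compound 2 at 35%. Compound 3 `COc1cc(-c2cnn3cc(OC)c([C@H]4COC(C)(C)C4)nc23)ccn1` departs from compound 1 at one place, on an aromatic carbon: a group of 7 heavy atoms (6 carbon, 1 oxygen; one five-membered non-aromatic ring with 1 hetero atom) in place of a group of 5 heavy atoms (4 carbon, 1 oxygen; one five-membered non-aromatic ring with 1 hetero atom), on an aromatic carbon. Going by the values given here, the two measured compounds differ in more than one place, so they offer no step to guide the expectation, which rests on the structural change alone. The expected change is a number 9 percentage points higher from compound 1 to compound 3 (within the scatter), a small upward move that may not clear the scatter. For compound 3 the estimated value is 38%, with an expected range from 22% to 56%.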

Compound 3, percent of the compound remaining: 21%
Compound 3: middle estimate off by 17 percentage points, on the high side, outside the stated range (below it).
By their numbers in this assay, from the lowest: compounds 3, 1 and 2 (each within the scatter of the next, the first and the last beyond it).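

In this assay, exchanging oxolan-3-yl on the aromatic carbon next to the ring nitrogen for the larger ring group, with its 7 heavy atoms and 1 defined stereocentre, gives a number 8 percentage points lower from compound 1 to compound 3 (within the scatter). This one-place comparison, which the earlier pair could not offer, shows that this enlargement of the ring group does not move the read-out beyond the scatter. Nothing shown bears on the reason for this result.

On these data alone, whether an amine or a carboxylic acid at this position, or a longer chain in place of the ring, would move the number beyond the scatter stays open. Also open, as far as these compounds go, is whether the opposite configuration at the stereocentre would read the same.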